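This account rests on a few compounds, and the source may have more. Where it says the series, first, only, none or still open, it means among the compounds named here.

Series notes. Compound 1 `Cc1cc(C)cc(S(=O)(=O)c2cnc3cc(F)ccc3c2N2CCC(C)CC2)c1` was measured in an assay on isolated protein for displacement of a labelled ligand from metabotropic glutamate receptor 5 (Homo sapiens), with a stated time of 60 min, tested at 1 uM (on this read-out higher numbers stand for more inhibition at the one concentration tested (going by the name of the read-out) and lower numbers for less inhibition), and gives 80%. Compound 2 `COCC1CCN(c2c(S(=O)(=O)c3ccc(F)cc3)cnc3cc(F)ccc23)CC1` gives 76.1% in this assay, and compound 3 `COc1ccc2ncc(S(=O)(=O)c3cccc(C#N)c3)c(N3CCC(C)CC3)c2c1` gives 90%. On these three numbers compound 1 sits between the other two; its gap to compound 2 and its gap to compound 3 both lie within the usual scatter, so no order among the three is asserted. Compound 4 `CC1CCN(c2c(S(=O)(=O)c3cc(Cl)cc(Cl)c3)cnc3cc(F)ccc23)CC1` is not yet measured. It differs from compound 1 in one place: 3,5-dichlorophenyl in place of 3,5-dimethylphenyl on a sulfonyl sulfur. The group entering on the sulfonyl sulfur matches the leaving group in ring and atom count, so the step from compound 1 to compound 4 is expected to be small, a number 2 percentage points lower from compound 1 to compound 4 (within the scatter), and not beyond the scatter. Compound 4 is estimated at 78%, with a range of 60% to 92%.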

Compound 4, a percentage reported as inhibition, at one concentration (the size of the read-out at that concentration, not a potency): 87%
Beside the measured number, compound 4's estimate is 9 percentage points below it, and the stated range covers the measured number.
By their numbers in this assay, from the lowest: compounds 2, 1, 4 and 3 (each within the scatter of the next, the first and the last beyond it).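

In this assay, among these compounds, the one step read so far on the sulfonyl sulfur, a number 7 percentage points higher from compound 1 to compound 4 (within the scatter), stays within the scatter. At this position, 3,5-dichlorophenyl can therefore replace 3,5-dimethylphenyl with no change beyond the scatter. Nothing at hand bears on why the two groups read alike. On these data alone, whether the position accepts a more different group, such as a phenyl ring carrying a carboxylic acid or an amine, stays open. A single-concentration read-out also leaves open whether compound 1 and compound 4 differ in potency.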